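The compounds below may be only part of what the source reports. "The series", "measured", "known", "first", "only" and "open" are said of these compounds alone.

Compound 1 `Nc1nc(N)c2c(-c3ccsc3)cn([C@@H]3O[C@H](CO)[C@@H](O)[C@H]3O)c2n1` gives > 20000 nM in a functional assay on HeLa S3 cells (Homo sapiens) for antiproliferative activity, read by XTT assay, with a stated time of 72 h (a higher number here means a weaker inhibitor, a lower number a stronger inhibitor), which is a limit of the measurement rather than a number.
Compound 2 `COc1nc(N)nc2c1c(-c1ccsc1)cn2[C@@H]1O[C@H](CO)[C@@H](O)[C@H]1O` gives > 20000 nM in this assay, again a limit.
Compound 3 `Cc1nc(N)c2c(-c3ccsc3)cn([C@@H]3O[C@H](CO)[C@@H](O)[C@H]3O)c2n1` gives > 20000 nM in this assay, again a limit.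

All three measured compounds share one core and differ only in the group on one aromatic carbon. Compound 1 stands at a limit, so its true value is not known, and the two measured steps, a step that the two limits leave unreadable from compound 1 to compound 2 and a step that the two limits leave unreadable from compound 1 to compound 3, cannot be read in size or direction because the limit of > 20000 nM in this assay, at which 3 of the 3 values shown sit, is where every value sits.

The compound to be measured is compound 4 `Nc1nc(N)c2c(-c3ccoc3)cn([C@@H]3O[C@H](CO)[C@@H](O)[C@H]3O)c2n1`. It differs from compound 1 by furan-3-yl in place of thiophen-3-yl on an aromatic carbon. Neither measured step changes this part of the molecule, so there is no direct guide to the size of the step from compound 1 to compound 4. The three measured compounds hold a thiophen-3-yl on that carbon and none reaches a number, so compound 4 is expected to behave much like them, with a step that the limit leaves unreadable from compound 1 to compound 4 that is estimated to stay within the usual scatter. Compound 4 is therefore estimated at 25000 nM, expected to lie between 8000 nM and 80000 nM, most likely reported only as a limit.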

Compound 4, half-maximal inhibitory concentration: > 20000 nM
Compound 4: only a limit was reported; the forecaster's own chance of this, stated with the estimate: 80%; the middle value is on the limit's open side.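

The step from compound 1 to compound 4, furan-3-yl in place of thiophen-3-yl, cannot be read in size or direction, because both compounds stand at a limit rather than a number: the limit of > 20000 nM in this assay, at which 4 of the 4 values shown sit. The compounds shown leave open what group on that aromatic carbon, if any, would give a real number in this assay.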